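A few compounds are considered here, and "the series" means these few. Any claim that something is new, unique, unknown or untested is made for them only; others in the source may bear on it.

Within the data shown here, compound 1 `CC(C)OC(=O)N1CCC(Oc2ncnc3c2CCN3c2ccc(S(C)(=O)=O)cc2F)CC1` carries an isopropyl group on an oxygen next to a carbonyl group; in a functional assay on CHO-K1 cells for agonist activity at Glucose-dependent insulinotropic receptor (Homo sapiens), read by a luciferase reporter, with a stated time of 5 h (on this read-out higher numbers stand for an effect only at larger amounts of compound and lower numbers for an effect already at smaller amounts), compound 1 gives 50.1 nM, the second highest of the three numbers so far. Compound 2 `CS(=O)(=O)c1ccc(N2CCc3c(OC4CCN(C(=O)OCCF)CC4)ncnc32)c(F)c1` gives 501 nM, and compound 3 `CS(=O)(=O)c1ccc(N2CCc3c(OC4CCN(C(=S)Sc5ccccc5)CC4)ncnc32)c(F)c1` gives 12.6 nM. Every measured step changes the group on the amine nitrogen in a ring: a 10-fold higher number from compound 1 to compound 2 (1.00 log units; beyond the scatter), a 4.0-fold lower number from compound 1 to compound 3 (0.60 log units; beyond the scatter) and a 40-fold lower number from compound 2 to compound 3 (1.60 log units; beyond the scatter). Compound 4 `CC(C)OC(=O)N1CCC(Oc2ncnc3c2CCN3c2ccc(S(C)(=O)=O)cn2)CC1` leaves that group as in compound 1 and instead alters the group on a nitrogen on an aromatic ring in a ring: 5-(methylsulfonyl)pyridin-2-yl in place of 2-fluoro-4-(methylsulfonyl)phenyl on a nitrogen on an aromatic ring in a ring. None of the three measured steps touches that position, and the group there is the same in compounds 1, 2 and 3, so no direct guide exists. Among the measured compounds shown here, with no comparable step in hand, the number for compound 4 is expected to stay close to that of compound 1, with the step of a 1.3-fold higher number from compound 1 to compound 4 (0.10 log units; within the scatter) expected to lie within or only slightly beyond the usual scatter. Compound 4 is therefore estimated at 63 nM, with a range from 20 nM to 200 nM.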

Compound 4, half-maximal effective concentration: 126 nM
For compound 4 the middle estimate is 2.0-fold (0.30 log units) below the measured one; the range from low to high includes it.
By their numbers in this assay, from the lowest: compound 3; then compound 1; then compound 4; then compound 2.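

Among these compounds, the group on a nitrogen on an aromatic ring in a ring proves able to move the number in this assay: 5-(methylsulfonyl)pyridin-2-yl in place of 2-fluoro-4-(methylsulfonyl)phenyl brings a 2.5-fold higher number from compound 1 to compound 4 (0.40 log units; beyond the scatter), the first reading at a position that all earlier steps left untouched. This exchange removes the fluorine and puts a nitrogen into the aromatic ring at once, so this single step cannot divide the shift between those two changes. Nothing at hand explains the shift at this position.

Still open, going by these compounds, is whether the same exchange would give a similar step with the groups of compound 2 or compound 3 on the amine nitrogen in a ring, as compound 4 keeps the isopropyl carbamate of compound 1. Also open, on these data alone, is what plain 4-(methylsulfonyl)phenyl without fluorine, a fluorinated pyridine, or an amine in place of methylsulfonyl would give.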